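The compounds below may be only part of what the source reports. "The series", "measured", "known", "first", "only" and "open" are said of these compounds alone.

In a functional assay on B16-F10 cells (Mus musculus) for antiproliferative activity, read by CCK-8 assay, with a stated time of 48 h (a lower number here means a stronger inhibitor, a higher number a weaker inhibitor), compound 1 `COc1ccc(/C=C\c2cc(OC)c(OC)c(OC)c2)cc1OCc1ccc(CN[C@H](C(=O)O)[C@H](C)O)cc1` gives > 10000 nM, which is a limit and not a number. Compound 2 `COc1ccc(/C=C\c2cc(OC)c(OC)c(OC)c2)cc1OCc1ccc(CN2CC(C(=O)O)C2)cc1` gives > 10000 nM, again a limit. Compound 3 `COc1ccc(/C=C\c2cc(OC)c(OC)c(OC)c2)cc1OCc1ccc(CN2CC[C@H](O)C2)cc1` gives > 10000 nM, also a limit, and so it stands with the other two at the limit of > 10000 nM in this assay, at which 3 of the 3 values shown sit.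

Compound 4 `COc1ccc(/C=C\c2cc(OC)c(OC)c(OC)c2)cc1OCc1ccc(CN2CCCCC2C(=O)NCCN)cc1` keeps the shared core and changes only the group on a saturated chain carbon bound to an aromatic carbon, where 2-((2-aminoethyl)carbamoyl)piperidin-1-yl takes the place of 3-hydroxypyrrolidin-1-yl: 2-((2-aminoethyl)carbamoyl)piperidin-1-yl in place of 3-hydroxypyrrolidin-1-yl on a saturated chain carbon bound to an aromatic carbon.

The measured steps that bear on this change are a step that the two limits leave unreadable from compound 1 to compound 3 and a step that the two limits leave unreadable from compound 2 to compound 3. A third, a step that the two limits leave unreadable from compound 1 to compound 2, also varies this group. None of them gives a size to carry over, so no step beyond the scatter is expected in this assay, and no direction can be expected with any confidence. The expected outcome is a number no higher from compound 3 to compound 4 (the limit leaves the size open), an estimate only. Compound 4 is estimated at 10000 nM, with an expected range from 1500 nM to 30000 nM.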

Compound 4, half-maximal inhibitory concentration: 4600 nM
The estimate for compound 4 lay 2.2-fold (0.34 log units) above the measured number, within the range that was stated.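

At this saturated chain carbon bound to an aromatic carbon, 2-((2-aminoethyl)carbamoyl)piperidin-1-yl is the only one of the four groups shown that gives a number rather than a limit in this assay: the limit of > 10000 nM in this assay, at which 3 of the 4 values shown sit.

In place of 3-hydroxypyrrolidin-1-yl it gives an at least 2.1-fold lower number from compound 3 to compound 4 (0.33 log units; beyond the scatter), in place of 3-carboxyazetidin-1-yl it gives an at least 2.1-fold lower number from compound 2 to compound 4 (0.33 log units; beyond the scatter), and in place of (1-carboxy-2-hydroxypropyl)amino it gives an at least 2.1-fold lower number from compound 1 to compound 4 (0.33 log units; beyond the scatter). The steps among compound 1, compound 2 and compound 3 cannot be read, so those three groups stay unranked.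

The compounds shown leave open which part of the entering group goes with the step: the six-membered ring, the carbonyl or the aminoethyl chain. They also leave open whether a longer chain in place of the 2-aminoethyl part would shift the number.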